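Swapping a propyl for a phenyl on the ether oxygen

A few compounds are considered here, and "the series" means these few. Any claim that something is new, unique, unknown or untested is made for them only; others in the source may bear on it.

Measured so far in a functional assay on ileum for inhibition of histamine H1 receptor (Cavia porcellus); a lower number here means a stronger inhibitor, a higher number a weaker inhibitor:
compound 1 `CCCOCCn1c(N2CCCN(C)CC2)nc2ccccc21` gives 16 nM
compound 2 `CCOCCn1c(N2CCNCC2)nc2ccccc21` gives 11 nM

Of these two numbers, compound 1 carries the higher one, yet its gap to compound 2 is within the usual scatter of repeated measurements, so the two compounds are not told apart by these values. The compound still to be measured is compound 3, `CN1CCCN(c2nc3ccccc3n2CCOc2ccccc2)CC1`. It differs from compound 1 in one place: phenyl in place of propyl on an oxygen on a saturated carbon. The two measured compounds differ from each other in more than one place, so they do not show how this change alone affects the read-out. With nothing in the measured pair to lean on, the step in this assay is expected to be small, possibly not beyond the scatter, and its direction is uncertain: a 1.3-fold lower number from compound 1 to compound 3 (0.12 log units; within the scatter). On that basis compound 3 is expected to give 12 nM, with a likely range from 4 nM to 40 nM.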

Compound 3, half-maximal inhibitory concentration: 9.1 nM
Compound 3: middle estimate off by 1.3-fold (0.12 log units), on the high side, within the range that was stated.
By their numbers in this assay, from the lowest: compounds 3, 2 and 1 (each within the scatter of the next).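

In this assay, replacing propyl with phenyl on an oxygen on a saturated carbon, with the rest of compound 1 unchanged, gives a 1.8-fold lower number from compound 1 to compound 3 (0.25 log units; within the scatter) and so does not tell the two compounds apart. This position therefore takes an aromatic ring in place of a straight chain with no shift beyond the scatter, which compound 1 and compound 2 could not show, as they differ in more than one place. Nothing available here explains this result.

As far as these compounds go, only propyl and phenyl can be compared at this position, so it remains open whether a benzyl group, a longer chain or a phenyl ring carrying an amine would read the same. From the compounds shown here alone, it is also open whether the same swap would give a similar step on the ethoxy-bearing structure of compound 2.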